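The compounds below may be only part of what the source reports. "The series", "measured", "known", "first", "only" and "open" are said of these compounds alone.

Three compounds of a shared core have been examined in a toxicity assay on HepG2 2.2.15 cells (Homo sapiens) for cytotoxicity, read by CellTiter-Glo; a higher number here means that more compound is tolerated, a lower number that less compound is tolerated. Compound 1 `O=C1CC(c2ccc(F)cn2)CN1c1cnn2c1CN(C(=O)Nc1cc(F)c(F)c(F)c1)C(C1CC1)C2` gives 38500 nM, and compound 2 `O=C1CC(c2ccccn2)CN1c1cnn2c1CN(C(=O)Nc1cc(F)c(F)c(F)c1)C(C1CC1)C2` gives 96200 nM. Compound 3 `Cc1nc(C2CC(=O)N(c3cnn4c3CN(C(=O)Nc3cc(F)c(F)c(F)c3)C(C3CC3)C4)C2)no1` reaches only the limit of the measurement, > 200000 nM, so its true number is not known. The step of an at least 5.1-fold higher number from compound 1 to compound 3 (0.71 log units; beyond the scatter) and the step of an at least 2.0-fold higher number from compound 2 to compound 3 (0.31 log units; beyond the scatter) both point the same way, toward more compound being tolerated, though each rests on (the limit of > 200000 nM in this assay, at which 1 of the 3 values shown sits). Compound 4 `O=C1CC(c2nccs2)CN1c1cnn2c1CN(C(=O)Nc1cc(F)c(F)c(F)c1)C(C1CC1)C2` carries 1,3-thiazol-2-yl in place of 5-methyl-1,2,4-oxadiazol-3-yl on a saturated ring carbon. Within the data shown here, since the only two steps onto compound 3 run upward, and compound 4 again bears a five-membered aromatic ring on that saturated ring carbon, the account expects the step of an at least 1.6-fold lower number from compound 3 to compound 4 (0.22 log units; that floor lies within the scatter) to be modest at most, possibly none beyond the scatter. Compound 4 is therefore expected to give 120000 nM, between 45000 nM and 250000 nM.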

Compound 4, half-maximal cytotoxic concentration: 115000 nM
For compound 4 the middle estimate is 1.0-fold (0.02 log units) above the measured one; low and high end bracket the measured number.
By their numbers in this assay, from the lowest: compound 1; then compounds 2 and 4 (each within the scatter of the next). At a limit, above all of these: compound 3.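

In this assay, 1,3-thiazol-2-yl on this saturated ring carbon is not told apart from pyridin-2-yl: a 1.2-fold higher number from compound 2 to compound 4 (0.08 log units; within the scatter). Against 5-fluoropyridin-2-yl the same position does show a difference, with a 3.0-fold higher number from compound 1 to compound 4 (0.48 log units; beyond the scatter). The step of an at least 1.7-fold lower number from compound 3 to compound 4 (0.24 log units; that floor lies within the scatter) gives only a floor, and compound 3 stands at a limit: the limit of > 200000 nM in this assay, at which 1 of the 4 values shown sits.

From the compounds shown here alone, the size of the gap between 5-methyl-1,2,4-oxadiazol-3-yl and 1,3-thiazol-2-yl stays open. So does the reading in this assay with a primary amine or a carboxylic acid on this carbon.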